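Isopropyl for oxan-4-yl on the ring nitrogen

A few compounds are considered here, and "the series" means these few. Any claim that something is new, unique, unknown or untested is made for them only; others in the source may bear on it.

Series notes. Compound 1 `Cc1cc(C)c(CNC(=O)c2cc(-c3ccc(N4CCNCC4)nc3)cc3c2C(C)CN3C2CCCC2)c(=O)[nH]1` is the reference point here; in an assay on isolated protein for inhibition of histone-lysine N-methyltransferase EZH2 (Homo sapiens), with a stated time of 1 h, in the presence of a further agent that is not named here (on this read-out lower numbers stand for stronger inhibition and higher numbers for weaker inhibition), compound 1 gives 378 nM; 21 nM (2 entries), and its repeat entries the several entries of compound 1 in this assay, 378 nM; 21 nM (2 entries) show how far one compound can spread on this read-out. For the measured compounds named here, compound 2 `Cc1cc(C)c(CNC(=O)c2cc(C#N)cc3c2CCN3C2CCOCC2)c(=O)[nH]1` carries a nitrile on the shared core and an oxan-4-yl on the ring nitrogen; in this assay compound 2 gives 15700 nM, the one single number it stands on, while a further entry for compound 2 in this assay holds no single number. Compound 3 `Cc1cc(C)c(CNC(=O)c2cc(C#N)cc3c2CCN3C(C)C)c(=O)[nH]1` differs from compound 2 in one place: isopropyl in place of oxan-4-yl on a nitrogen on an aromatic ring in a ring. Going by the values given here, no measured pair shows that exchange, so no step size can be read from the data; the expectation is for a step of no size beyond the usual scatter, in either direction. The step from compound 2 to compound 3 is expected to be a 1.3-fold lower number from compound 2 to compound 3 (0.12 log units; within the scatter). Compound 3 is estimated at 12000 nM in this assay, with a range from 4000 nM to 40000 nM.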

Compound 3, half-maximal inhibitory concentration: 26800 nM
Compound 3: middle estimate off by 2.2-fold (0.35 log units), on the low side; the range from low to high includes it.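

In this assay, isopropyl in place of oxan-4-yl on a nitrogen on an aromatic ring in a ring gives a 1.7-fold higher number from compound 2 to compound 3 (0.23 log units; within the scatter). This is the first measured pair at this position, and it does not separate the two groups: with the nitrile on the shared core, the open isopropyl and the six-membered ring with its one hydrogen-bond acceptor read alike, so in this pair neither the ring nor the acceptor is shown to matter. The size of this one step should not be over-read, because repeat entries of a single compound can lie far apart on this read-out: the several entries of compound 1 in this assay, 378 nM; 21 nM (2 entries)

Both compounds of the pair sit at the weak end of the numbers shown and both carry the nitrile, so whether the same exchange would read alike with another group in place of the nitrile remains open. Also open, from the compounds shown here alone, is whether a ring carrying an amine, such as piperidin-4-yl, or a carboxylic acid on a longer chain at this nitrogen would give a step beyond the usual scatter.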